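Removing one methoxy from compound 2: a cytotoxicity estimate

A few compounds are considered here, and "the series" means these few. Any claim that something is new, unique, unknown or untested is made for them only; others in the source may bear on it.

Measured compounds:
- compound 1, `CCOC(=O)/C=C/c1ccc(OC(=O)c2nc(C)c(C)nc2C)c(O)c1`: 75.7%
- compound 2, `CCOC(=O)/C=C/c1cc(OC)c(OC(=O)c2nc(C)c(C)nc2C)c(OC)c1`: 96.6%

Within the data shown here, in a functional assay on EA.hy 926 cells (Homo sapiens) for cytotoxicity, read by MTT assay, with stated times of 24 h and 12 h, tested at 12.5 uM (on this read-out lower numbers stand for a weaker effect and higher numbers for a stronger effect at the one concentration tested), compound 2 gives 96.6%, the higher of the two values measured so far. Compound 1 gives 75.7% in this assay, a number that sits well beyond the usual scatter below compound 2. Compound 3, `CCOC(=O)/C=C/c1ccc(OC(=O)c2nc(C)c(C)nc2C)c(OC)c1`, has not yet been measured. It differs from compound 2 in one place: hydrogen in place of methoxy on an aromatic carbon. Among the measured compounds shown here, no step between two measured compounds isolates this change, so there is no direct precedent for its size. Compound 1, which lacks both methoxy groups of compound 2 and carries a hydroxyl instead, sits lower, and compound 3 lies between those two structures. A modest downward step is therefore expected, a number 10.6 percentage points lower from compound 2 to compound 3 (beyond the scatter), and compound 3 is estimated to give 86% in this assay, expected between 68% and 100%.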

Compound 3, a percentage reported as activity, at one concentration (the size of the read-out at that concentration, not a potency): 52.4%
Beside the measured number, compound 3's estimate is 33.6 percentage points above it; the measured number lies below the stated range.
By their numbers in this assay, from the lowest: compound 3; then compound 1; then compound 2.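

In this assay, the methoxy that sits ortho to a large group and meta to a 2-(ethoxycarbonyl)ethenyl group proves far from silent, as its replacement by hydrogen gives a number 44.2 percentage points lower from compound 2 to compound 3 (beyond the scatter) in a single change. The remaining oxygen matters too: methyl in place of the hydroxyl hydrogen gives a number 23.3 percentage points lower from compound 1 to compound 3 (beyond the scatter) and so lowers the number rather than raising it. No measurement shown explains either step.

The compounds shown carry only methoxy or hydrogen at the first position, so how an ethoxy group, a fluorine atom or an amine would read there stays open. As far as these compounds go, whether these steps would hold at another concentration or in another cell line also stays open.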